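The compounds below may be only part of what the source reports. "The series", "measured", "known", "first", "only" and "open" are said of these compounds alone.

Measured so far:
compound 1 `ClCc1cccc(Cn2cnc3ncnc(Cl)c32)c1`, 15100 nM
compound 2 `ClCc1cccc(Cn2cnc3c(Cl)nc(Cl)nc32)c1`, 1580 nM

Among the measured compounds shown here, in a functional assay on SW-620 cells (Homo sapiens) for cytotoxicity, read by sulforhodamine B assay, with a stated time of 48 h (a lower number here means a stronger inhibitor of growth, a higher number a weaker inhibitor of growth), compound 1 gives 15100 nM, the highest of the two numbers; compound 2 sits a good way lower, beyond the scatter, but the two differ in more than one place, so no single step connects them. Compound 3 `ClCc1cccc(Cn2cnc3nc(Cl)nc(Cl)c32)c1` is not yet measured. It differs from compound 1 by chloro in place of hydrogen on an aromatic carbon. Compound 2 carries the same pair of chloro groups on its core, and its value suggests that a second chloro can go with a lower number. A step of moderate size toward a lower number is expected, a 5.0-fold lower number from compound 1 to compound 3 (0.70 log units; beyond the scatter). For compound 3 the estimate is 3000 nM, with a range from 900 nM to 10000 nM.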

Compound 3, concentration for 50% growth inhibition: 410 nM
Estimate against measurement, compound 3: 7.3-fold (0.86 log units) above; the measured number lies below the stated range.
By their numbers in this assay, from the lowest: compound 3; then compound 2; then compound 1.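

In this assay, chloro in place of hydrogen on an aromatic carbon, on the six-membered aromatic ring with 2 nitrogen and between two ring nitrogen atoms, gives a 37-fold lower number from compound 1 to compound 3 (1.57 log units; beyond the scatter). This position therefore responds strongly to a single added heavy atom, on a core already carrying one chloro group. No measurement on hand accounts for the size of this step.

Going by these compounds, whether an amine, a methoxy group or a fluoro group at this position would give a similarly low number remains open. Also open, on these data alone, is whether the step holds in other cell lines.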